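The source may report more compounds than this note shows. Statements on the series, on what has been measured and on what is new or still open speak of the compounds shown alone.

Compound 2, with the structure `CS(=O)(=O)c1ccc(F)cc1NCC1=NCCN1`, was tested in a functional assay for agonist activity at Alpha-1A adrenergic receptor (Homo sapiens) (on this read-out lower numbers stand for an effect already at smaller amounts and higher numbers for an effect only at larger amounts of compound), and gave 16.6 nM. Among the two compounds measured so far, compound 2 stands at the highest number. The other measured compound, compound 1 with the structure `CSc1ccc(C)cc1NCC1=NCCN1`, gives in this assay a value of 0.11 nM; the gap between these two numbers lies well beyond the usual scatter of such measurements. Among the compounds with values here, compound 1 and compound 2 differ in more than one place, so no single step between them is known.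

The next compound, compound 3 with the structure `CSc1ccc(F)cc1NCC1=NCCN1`, has not yet been measured. It arises from compound 2 through one change: methylsulfanyl in place of methylsulfonyl on an aromatic carbon. The group that enters is the same sulfur group that compound 1 carries, and compound 1 shows the lower number of the two, so the step from compound 2 to compound 3 is expected to lower the number, probably well beyond the scatter, with a 28-fold lower number from compound 2 to compound 3 (1.44 log units; beyond the scatter) as the estimated size. On that basis compound 3 is expected to give about 0.6 nM, within a range from 0.1 nM to 4 nM.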

Compound 3, half-maximal effective concentration: 2.29 nM
For compound 3 the middle estimate is 3.8-fold (0.58 log units) below the measured one, within the range that was stated.
By their numbers in this assay, from the lowest: compound 1; then compound 3; then compound 2.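

In this assay, methylsulfanyl in place of methylsulfonyl on this aromatic carbon gives a 7.2-fold lower number from compound 2 to compound 3 (0.86 log units; beyond the scatter) with everything else in the compound unchanged, so the sulfur group at this place moves the number by itself, which compounds 1 and 2 could not show as they also differ elsewhere. With methylsulfanyl held fixed, fluoro in place of methyl on an aromatic carbon gives a 21-fold higher number from compound 1 to compound 3 (1.32 log units; beyond the scatter) and shows that this second site also moves the number, with methyl on the side of the lower value. No measurement shown here explains why either change has this effect.

The compounds shown cover only two sulfur groups at the first place and only methyl and fluoro at the second, so it remains open how a methoxy group or an amine would behave at the first, or a chloro group or a plain hydrogen at the second. It is also open whether the change between the two sulfur groups would have the same size with methyl in place of fluoro, as only the fluoro pair is shown.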